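Bromo in place of hydrogen: compound 3 to compound 4

This account rests on a few compounds, and the source may have more. Where it says the series, first, only, none or still open, it means among the compounds named here.

In a functional assay on HepG2 cells (Homo sapiens) for cytotoxicity, read by MTT assay, with a stated time of 72 h (on this read-out lower numbers stand for stronger inhibition and higher numbers for weaker inhibition), compound 3 `CNC(=O)c1cc(Oc2ccc(C3=NNC(c4ccccc4)C3)cc2)ccn1` gives 1500 nM and compound 2 `CNC(=O)c1cc(Oc2ccc(C3=NNC(c4cccc(Br)c4)C3)cc2)ccn1` gives 1850 nM, two numbers within the scatter of each other. For compound 1 `CNC(=O)c1cc(Oc2ccc(C3=NNC(c4ccc(Cl)cc4Cl)C3)cc2)ccn1` the entry reads "not determined" (no result reported). Compound 4 `CNC(=O)c1cc(Oc2ccc(C3=NNC(c4ccc(Br)cc4)C3)cc2)ccn1` differs from compound 3 by bromo in place of hydrogen on an aromatic carbon, para to a large group: bromo in place of hydrogen on an aromatic carbon. Going by the values given here, the one measured step that bears on this is a 1.2-fold lower number from compound 2 to compound 3 (0.09 log units; within the scatter), the same exchange run the other way at a different place on the ring. No change beyond the scatter is therefore expected, and the expected step is a 1.1-fold higher number from compound 3 to compound 4 (0.05 log units; within the scatter). The estimated value for compound 4 is 1700 nM, with a range from 800 nM to 3500 nM.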

Compound 4, half-maximal inhibitory concentration: 57600 nM
The estimate for compound 4 lay 34-fold (1.53 log units) below the measured number; measured number outside the range, above it.
By their numbers in this assay, from the lowest: compounds 3 and 2 (each within the scatter of the next); then compound 4.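

Bromo is not a neutral exchange on this ring: in this assay, phenyl to 4-bromophenyl gives a 38-fold higher number from compound 3 to compound 4 (1.58 log units; beyond the scatter), although the 3-bromophenyl of compound 2 stays within the scatter of the phenyl of compound 3. Likewise, 4-bromophenyl in place of 3-bromophenyl gives a 31-fold higher number from compound 2 to compound 4 (1.49 log units; beyond the scatter), so among these compounds the outcome depends on where the bromo stands, not on its presence alone. Nothing available here accounts for this loss.

Going by these compounds, whether the loss is specific to bromo remains open, as does how a fluoro, a methoxy or an amine would behave in the same place. Compound 1 has no number and cannot help settle this.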